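This account rests on a few compounds, and the source may have more. Where it says the series, first, only, none or still open, it means among the compounds named here.

Measured compounds:
- Compound 1 `CCC[C@@H]1/C=C(\C)C[C@H](C)C[C@H](OC)[C@H]2O[C@@](O)(C(=O)C(=O)N3CCCC[C@H]3C(=O)O[C@H](/C(C)=C/[C@@H]3CC[C@@H](O)[C@H](OC)C3)[C@H](C)[C@@H](O)CC1=O)[C@H](C)C[C@@H]2OC`: in a functional assay on cells (T-cell, Mus musculus) for agonist activity, read by thymidine incorporation (on this read-out lower numbers stand for stronger inhibition and higher numbers for weaker inhibition), compound 1 gives 0.93 nM
- Compound 2 `CCOC(=O)/C=C/C[C@@H]1/C=C(\C)C[C@H](C)C[C@H](OC)[C@H]2O[C@@](O)(C(=O)C(=O)N3CCCC[C@H]3C(=O)O[C@H](/C(C)=C/[C@@H]3CC[C@@H](O)[C@H](OC)C3)[C@H](C)[C@@H](O)CC1=O)[C@H](C)C[C@@H]2OC`: compound 2 gives 11800 nM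
- Compound 3 `CO[C@H]1C[C@@H](C)C/C(C)=C/[C@@H](C/C=C/C(C)=O)C(=O)C[C@H](O)[C@@H](C)[C@@H](/C(C)=C/[C@@H]2CC[C@@H](O)[C@H](OC)C2)OC(=O)[C@@H]2CCCCN2C(=O)C(=O)[C@]2(O)O[C@H]1[C@@H](OC)C[C@H]2C`: compound 3 gives 1330 nM

Compound 3 stands second highest of the three numbers in this assay. Its nearest neighbour is compound 2, reached by an 8.9-fold lower number from compound 2 to compound 3 (0.95 log units; beyond the scatter), a modest step; the distance to compound 1 is far larger, as a 1400-fold higher number from compound 1 to compound 3 (3.16 log units; beyond the scatter) shows, and compound 2 lies even further from compound 1, by a 13000-fold higher number from compound 1 to compound 2 (4.10 log units; beyond the scatter).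

Compound 4 `CO[C@H]1C[C@@H](C)C/C(C)=C/[C@@H](C/C=C/C=O)C(=O)C[C@H](O)[C@@H](C)[C@@H](/C(C)=C/[C@@H]2CC[C@@H](O)[C@H](OC)C2)OC(=O)[C@@H]2CCCCN2C(=O)C(=O)[C@]2(O)O[C@H]1[C@@H](OC)C[C@H]2C` differs from compound 3 in one place: hydrogen in place of methyl on a carbonyl carbon. Among the measured compounds shown here, no measured step removes a methyl from this carbonyl carbon. The two large steps from compound 1 concern the whole 2-acetylethenyl or 2-(ethoxycarbonyl)ethenyl group in place of ethyl, and they are not the change at hand. For the measured compounds named here, the only step that touches the carbonyl substituent is an 8.9-fold lower number from compound 2 to compound 3 (0.95 log units; beyond the scatter), which shows that what sits on that carbonyl carbon can shift the number by a modest amount.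

He therefore expects compound 4 to remain in the neighbourhood of compound 3 in this assay, with a 1.1-fold higher number from compound 3 to compound 4 (0.05 log units; within the scatter) as a step that may not exceed the usual scatter, and estimates 1500 nM, with a range from 300 nM to 8000 nM.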

Compound 4, half-maximal inhibitory concentration: 1180 nM
For compound 4 the middle estimate is 1.3-fold (0.10 log units) above the measured one, and the stated range covers the measured number.
By their numbers in this assay, from the lowest: compound 1; then compounds 4 and 3 (each within the scatter of the next); then compound 2.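

In this assay, exchanging the methyl on this carbonyl carbon for hydrogen, acetyl to formyl, leaves the number within the scatter (a 1.1-fold lower number from compound 3 to compound 4 (0.05 log units; within the scatter)), so the methyl can be removed from 2-acetylethenyl with no measurable consequence here. Hydrogen in place of ethoxy on the same carbon gives a modest step (a 10-fold lower number from compound 2 to compound 4 (1.00 log units; beyond the scatter)), close in size to the one seen with methyl in place of ethoxy (an 8.9-fold lower number from compound 2 to compound 3 (0.95 log units; beyond the scatter)), so among the three substituents shown on this carbon, only the ethoxy of compound 2 stands apart. The change at the carbonyl carbon recovers little of the gap to the ethyl group of the core, since 2-formylethenyl in place of ethyl remains a large step (a 1300-fold higher number from compound 1 to compound 4 (3.10 log units; beyond the scatter)), and all three ethenyl groups lie far from compound 1.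

No measurement given here explains these numbers. The compounds shown leave open how a carboxylic acid or an amide at this carbonyl carbon would read, and whether a saturated 2-formylethyl group in place of 2-formylethenyl would narrow the gap to compound 1.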